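A few compounds are considered here, and "the series" means these few. Any claim that something is new, unique, unknown or untested is made for them only; others in the source may bear on it.

Measured in a functional assay on HepG2 cells (Homo sapiens) for cytotoxicity, read by MTT assay, with a stated time of 48 h; a higher number here means a weaker inhibitor, a lower number a stronger inhibitor:
compound 1 `O=[N+]([O-])c1ccc2[nH]c(CSCc3nc4ccccc4[nH]3)nc2c1`: 11200 nM
compound 2 `O=C(CSCc1nc2cc([N+](=O)[O-])ccc2[nH]1)c1ccccc1`: 16100 nM
compound 3 `N#Cc1sc(Nc2ccccc2)nc1NC(=O)CSCc1nc2cc([N+](=O)[O-])ccc2[nH]1`: 9480 nM

The three compounds are structurally distinct, yet their values sit close together. Compound 2, at 16100 nM, lies within the scatter of both compound 1 and compound 3, so this assay does not separate it from either. For the measured compounds named here, no two of the measured compounds differ in one place only, which leaves no measured step to serve as a direct guide.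

The next compound to be tested is compound 4 `NC(=O)CSCc1nc2cc([N+](=O)[O-])ccc2[nH]1`. It departs from compound 2 by a single change, amino in place of phenyl on a carbonyl carbon. The effect of this change has not been measured in any other pair of these compounds. The expectation therefore rests on the narrow spread of the existing values, with compound 1 at 11200 nM and compound 3 at 9480 nM. No step beyond the scatter is expected in this assay, and the estimated step is a 1.2-fold lower number from compound 2 to compound 4 (0.06 log units; within the scatter). Compound 4 is expected to give 14000 nM, with an estimated range from 6000 nM to 35000 nM.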

Compound 4, half-maximal inhibitory concentration: 26900 nM
For compound 4 the middle estimate is 1.9-fold (0.28 log units) below the measured one; measured number inside the range.
By their numbers in this assay, from the lowest: compounds 3, 1, 2 and 4 (each within the scatter of the next, the first and the last beyond it).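

For the compounds shown here, the pair of compound 2 and compound 4 gives the first measured one-place step in this set, at a carbonyl carbon whose other neighbour is a saturated chain carbon. In this assay amino in place of phenyl on this carbon gives a 1.7-fold higher number from compound 2 to compound 4 (0.22 log units; within the scatter) and so does not separate the two compounds, even though the change removes a whole six-membered aromatic ring of carbon only and brings in one hydrogen-bond donor. The phenyl ring is thus not shown to matter for the reading at this position, and no measured information in hand bears on this result.

From the compounds shown here alone, whether other groups on the same carbonyl carbon, such as a dimethylamino group, a hydroxyl group giving a carboxylic acid, or a longer chain ending in an amine, would also stay within the scatter of compound 2 remains open. Going by these compounds alone, it is also open whether amino in place of phenyl would give a similar step on a core other than the one shared by compound 2 and compound 4, since this change is seen in this one pair only.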